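A few compounds are considered here, and "the series" means these few. Any claim that something is new, unique, unknown or untested is made for them only; others in the source may bear on it.

Measured so far in a functional assay on MCF7 cells (Homo sapiens) for inhibition, read by sulforhodamine B assay, with a stated time of 48 h, tested at 10 uM; on this read-out lower numbers stand for less inhibition and higher numbers for more inhibition at the one concentration tested (going by the name of the read-out):
- compound 1 `Brc1cn2ccnc2c(-c2ccc3ncn(C4CCCCC4)c3c2)n1`: 47.6%
- compound 2 `COc1ccc(-c2cn3ccnc3c(-c3ccc4ncn(C5CCCCC5)c4c3)n2)cc1`: 80.2%
- compound 3 `Fc1ccc(-c2cn3ccnc3c(-c3ccc4ncn(C5CCCCC5)c4c3)n2)cc1`: 9.17%

Compound 1 sits second highest of the three numbers: compound 2 lies above it by a number 32.6 percentage points higher from compound 1 to compound 2 (beyond the scatter) and compound 3 below it by a number 38.4 percentage points lower from compound 1 to compound 3 (beyond the scatter), both beyond the scatter.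

Compound 4 `FC(F)(F)c1cccc(-c2cn3ccnc3c(-c3ccc4ncn(C5CCCCC5)c4c3)n2)c1` differs from compound 1 as follows: 3-(trifluoromethyl)phenyl in place of bromo on an aromatic carbon. Among the measured compounds shown here, the steps that bear on it are the two other aryl-for-bromo replacements at the same position. They ran in opposite directions: a large rise with 4-methoxyphenyl, a large fall with 4-fluorophenyl, and between those two aryl compounds the gap is a number 71 percentage points lower from compound 2 to compound 3 (beyond the scatter). For the measured compounds named here, a 3-(trifluoromethyl)phenyl carries neither a methoxy nor a fluoro at the para position, so no measured step settles which way it falls. The expectation for compound 4 is therefore a step of a number 9.6 percentage points lower from compound 1 to compound 4 (within the scatter) in this assay, with wide uncertainty spanning both directions. Compound 4 is estimated at 38%, likely between 8% and 72%.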

Compound 4, a percentage reported as inhibition, at one concentration (the size of the read-out at that concentration, not a potency): 19.9%
For compound 4 the middle estimate is 18.1 percentage points above the measured one, within the range that was stated.
By their numbers in this assay, from the lowest: compound 3; then compound 4; then compound 1; then compound 2.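

In this assay, the 3-(trifluoromethyl)phenyl replacement gives a number 27.7 percentage points lower from compound 1 to compound 4 (beyond the scatter), so two of the three aryl groups at this position now fall short of the bromo group, with 4-methoxyphenyl the one exception. The other two steps, a number 10.7 percentage points higher from compound 3 to compound 4 (beyond the scatter) and a number 60.3 percentage points lower from compound 2 to compound 4 (beyond the scatter), show that the new aryl group lies much nearer to 4-fluorophenyl than to 4-methoxyphenyl, so an aryl group here does not by itself raise the number. No supporting data are available to explain these differences.

The aryl groups differ in both the substituent and its place on the ring, so these two changes cannot be separated. From the compounds shown here alone, whether a 3-methoxyphenyl or a 4-(dimethylamino)phenyl would keep the high number of compound 2 remains open.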